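The source may hold more compounds than are shown below. What is called first, only, known or untested is meant among the compounds shown, and "the series" means these compounds.

Of the compounds shown here, two have been measured in a functional assay on MCF7 cells (Homo sapiens) for inhibition, read by MTT assay, with a stated time of 48 h; a higher number here means a weaker inhibitor, a lower number a stronger inhibitor. Compound 1 `O=C(C=CNc1cc(-c2ccccc2)nn1-c1ccccc1)c1ccc(Cl)cc1` gives 8070 nM in this assay, which is the highest of the two numbers and therefore the weaker result of the pair. Compound 2 `COc1ccc(-c2nc3c(c(-c4ccccc4)nn3-c3ccccc3)c(-c3ccc(N4CCN(C)CC4)cc3)c2C#N)cc1`, built on a different core, gives 2650 nM in this assay, a lower number than compound 1 and beyond the scatter of repeated measurements.

Compound 3 `O=C(C=CNc1cc(-c2ccccc2)nn1-c1ccccc1)c1ccc(F)cc1` has not yet been measured in this assay. It is compound 1 with one change: fluoro in place of chloro on an aromatic carbon. For the measured compounds named here, no pair of measured compounds shows this kind of swap, so there is nothing in the data to say how large its effect should be. Exchanging one halogen for another at the same spot usually moves a number only a little, and a small shift toward a higher number is expected, as the step of a 1.2-fold higher number from compound 1 to compound 3 (0.09 log units; within the scatter). Compound 3 is therefore estimated at 10000 nM in this assay, with a likely range from 4000 nM to 25000 nM.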

Compound 3, half-maximal inhibitory concentration: 9180 nM
Estimate against measurement, compound 3: 1.1-fold (0.04 log units) above; low and high end bracket the measured number.
By their numbers in this assay, from the lowest: compound 2; then compounds 1 and 3 (each within the scatter of the next).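

In this assay, the step from 4-chlorophenyl to 4-fluorophenyl reads a 1.1-fold higher number from compound 1 to compound 3 (0.06 log units; within the scatter). For the compounds shown here, this is the first pair here that differs in only one place, and it shows that, at this spot on a six-membered aromatic ring, the two halogens cannot be told apart in this read-out. No available measurement explains why they read alike.

Both groups are halogens, so the compounds shown leave open what a plain hydrogen, a hydroxyl group or a carboxylic acid would do at the same spot. They also leave open whether changes elsewhere on the core shared by compound 1 and compound 3 would have a larger effect than this exchange of one halogen for another.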